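Fluorinated sulfonyl aryl variants of the shared core

A few compounds are considered here, and "the series" means these few. Any claim that something is new, unique, unknown or untested is made for them only; others in the source may bear on it.

Compound 3 `COc1ccc(-c2cc(=O)c3c(OC)cc(OC)cc3n2S(=O)(=O)c2cc(F)c(F)c(F)c2)cc1` carries a 3,4,5-trifluorophenyl group on the sulfonyl sulfur. In a functional assay on KOPN-8 cells (Homo sapiens) for antiproliferative activity, with a stated time of 72 h (on this read-out lower numbers stand for an effect already at smaller amounts and higher numbers for an effect only at larger amounts of compound), compound 3 reaches only the limit > 65500 nM and no number. Compound 2 `COc1ccc(-c2cc(=O)c3c(OC)cc(OC)cc3n2S(=O)(=O)c2ccc([N+](=O)[O-])cc2)cc1`, with 4-nitrophenyl in that position, gives 17300 nM in this assay. Compound 1 `COc1ccc(-c2cc(=O)c3c(OC)cc(OC)cc3n2S(=O)(=O)c2ccc(C=O)cc2)cc1` stops at the limit > 34400 nM in this assay, again not a number. The step of an at least 3.7-fold higher number from compound 2 to compound 3 (0.57 log units; beyond the scatter) is the only readable one that touches compound 3; the step that the two limits leave unreadable from compound 1 to compound 3 gives nothing, and the step of an at least 1.9-fold lower number from compound 1 to compound 2 (0.29 log units; that floor lies within the scatter) stays within the scatter. Compound 4 `COc1ccc(-c2cc(=O)c3c(OC)cc(OC)cc3n2S(=O)(=O)c2c(F)c(F)c(F)c(F)c2F)cc1` differs from compound 3 by 2,3,4,5,6-pentafluorophenyl in place of 3,4,5-trifluorophenyl on a sulfonyl sulfur. Among the measured compounds shown here, no measured step tests a change of this kind; the only step that bears on it is an at least 3.7-fold higher number from compound 2 to compound 3 (0.57 log units; beyond the scatter), and compound 3 itself stands at the limit of > 65500 nM in this assay, at which 1 of the 3 values shown sits. For compound 4 the expectation is therefore again no readable number, and the step that the limit leaves unreadable from compound 3 to compound 4 is expected to stay within the scatter. Compound 4 is estimated at 80000 nM, within 20000 nM to 300000 nM.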

Compound 4, half-maximal effective concentration: > 34400 nM
Compound 4 ended at the assay's limit; the forecaster's own chance of this, stated with the estimate: 80%; the middle value is on the limit's open side.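

Compound 4 stops at a limit in this assay, > 34400 nM, which is not a number, so 2,3,4,5,6-pentafluorophenyl on the sulfonyl sulfur is a second fluorinated aryl group without a readable value. Among the compounds shown here, the only readable step is an at least 1.9-fold higher number from compound 2 to compound 4 (0.29 log units; that floor lies within the scatter), so this floor does not separate compound 4 from compound 2, whereas the step of an at least 3.7-fold higher number from compound 2 to compound 3 (0.57 log units; beyond the scatter) did for compound 3. The steps to compound 4 from compound 1 and compound 3 cannot be read, so the effect of going from 3,4,5-trifluorophenyl to 2,3,4,5,6-pentafluorophenyl stays unknown, and one limit now covers two compounds: the limit of > 34400 nM in this assay, at which 2 of the 4 values shown sit.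

Among the compounds shown, only compound 2 gives a number, 17300 nM. From the compounds shown here alone, whether an amine or a carboxylic acid on the phenyl ring, or a longer chain on the sulfonyl sulfur, would give a number clearly apart from it stays open.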